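Shortening the piperidinyl chain on compound 3

The source may report more compounds than this note shows. Statements on the series, on what has been measured and on what is new or still open speak of the compounds shown alone.

Compound 3 `O=C1c2c[n+]([O-])c3ccccc3c2C(=O)c2c1c1ccccc1n2CCCCN1CCCCC1` carries a 4-(piperidin-1-yl)butyl group on the aromatic nitrogen of the shared core. In a functional assay on HCT-116 cells (Homo sapiens) for cytotoxicity, read by MTT assay, with a stated time of 72 h (on this read-out lower numbers stand for stronger inhibition and higher numbers for weaker inhibition), compound 3 gives 200 nM, the highest of the three numbers measured. Compound 1 `CC1(C)OCC(Cn2cc(Cn3c4c(c5ccccc53)C(=O)c3c[n+]([O-])c5ccccc5c3C4=O)nn2)O1` gives 70 nM and compound 2 `O=C1c2c[n+]([O-])c3ccccc3c2C(=O)c2c1c1ccccc1n2Cc1cn([C@@H]2C[C@H](O)[C@@H](CO)O2)nn1` gives 50 nM in this assay; both gaps to compound 3 lie beyond the scatter. Within the data shown here, the one measured step, a 1.4-fold lower number from compound 1 to compound 2 (0.15 log units; within the scatter), exchanges one oxygen-bearing group for another on the aromatic nitrogen and stays within the scatter. Compound 4 `O=C1c2c[n+]([O-])c3ccccc3c2C(=O)c2c1c1ccccc1n2CCN1CCCCC1` differs from compound 3 by piperidin-1-yl in place of 2-(piperidin-1-yl)ethyl on a saturated chain carbon, two bonds along the chain from an aromatic nitrogen; the piperidine ring is retained and only the chain between it and the aromatic nitrogen is shortened. Among the measured compounds shown here, no measured step touches chain length in this position, so the single measured step bears on it only loosely and gives no direction. In this assay the expected outcome for compound 4 is therefore a step no larger than the scatter, no change at the digits printed from compound 3 to compound 4 (within the scatter). Compound 4 is estimated at 200 nM, with a range of 80 nM to 500 nM.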

Compound 4, half-maximal inhibitory concentration: 780 nM
Compound 4: the middle estimate sits 3.9-fold (0.59 log units) below what was measured; measured number outside the range, above it.
By their numbers in this assay, from the lowest: compounds 2 and 1 (each within the scatter of the next); then compound 3; then compound 4.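

In this assay the chain on the aromatic nitrogen proves to be a sensitive position: with the piperidine ring kept, going from 4-(piperidin-1-yl)butyl to 2-(piperidin-1-yl)ethyl gives a 3.9-fold higher number from compound 3 to compound 4 (0.59 log units; beyond the scatter) and so lies beyond the scatter. Among these compounds, the only earlier step, a 1.4-fold lower number from compound 1 to compound 2 (0.15 log units; within the scatter) and within the scatter, did not touch chain length. Within this one pair, the shorter chain therefore goes with weaker inhibition, so chain length alone can move the number.

The two lengths shown do not settle whether the number changes steadily along the chain or whether 3-(piperidin-1-yl)propyl or a longer chain such as 5-(piperidin-1-yl)pentyl breaks the trend, nor whether a morpholine ring in place of piperidine follows it. Nothing available explains why the number moves with chain length.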